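The source may hold more compounds than are shown below. What is called first, only, known or untested is meant among the compounds shown, and "the series" means these compounds.

In an ADME assay on MRC5 cells (Homo sapiens) for cytotoxicity, read by fluorescence and resazurin assay, with a stated time of 3 days (on this read-out lower numbers stand for stronger inhibition and higher numbers for weaker inhibition), compound 1 (`Cc1ccc(Oc2cccc(CN3CCC(n4cc(C)c(=O)[nH]c4=O)CC3)c2)cc1`) gives > 64000 nM, which is a limit of the assay and not a number. Compound 2 (`Cc1cn(C2CCN(Cc3cccc(Oc4ccccc4)c3)CC2)c(=O)[nH]c1=O`) has no single number, as its result reads "not determined" (no result reported). The only firm reference point is therefore (the limit of > 64000 nM in this assay, at which 1 of the 2 values shown sits). Compound 3 (`Cc1cn(C2CCN(Cc3cccc(Oc4cccc(Cl)c4)c3)CC2)c(=O)[nH]c1=O`) carries one structural change, (chloro in place of hydrogen on an aromatic carbon), with chloro in place of hydrogen on an aromatic carbon. Among the measured compounds shown here, no measured step guides this change, so a small move towards stronger inhibition in this assay is expected. For compound 3 the estimated value is 50000 nM, with an expected range of 20000 nM to 64000 nM.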

Compound 3, half-maximal inhibitory concentration: 21000 nM
Estimate against measurement, compound 3: 2.4-fold (0.38 log units) above; the range from low to high includes it.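

In this assay, among the compounds shown here, compound 3 gives 21000 nM, the first firm number here, so cytotoxicity can be measured with 3-chlorophenoxy at this position. Here an at least 3.0-fold lower number from compound 1 to compound 3 (0.48 log units; beyond the scatter) is the one comparison that can be read. The reading for compound 1 is a limit of the assay and not a number: the limit of > 64000 nM in this assay, at which 1 of the 3 values shown sits.

The step from hydrogen to chloro cannot be read, as compound 2 has no result. From the compounds shown here alone, whether fluoro, methoxy or an amine on this ring would give a lower or higher number stays open.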